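This account rests on a few compounds, and the source may have more. Where it says the series, first, only, none or still open, it means among the compounds named here.

Measured in an assay on HEK293 cells for negative allosteric modulation of metabotropic glutamate receptor 5 (Homo sapiens), read by FLIPR, with a stated time of 1 h; a lower number here means a stronger inhibitor, a higher number a weaker inhibitor:

- compound 1 `O=C(C1CC12CCC2)N1CCc2nc(C#Cc3ccccc3)sc2C1`: > 10000 nM
- compound 2 `O=C(C1CCC(F)(F)CC1)N1CCc2nc(C#Cc3ccccc3)sc2C1`: > 10000 nM
- compound 3 `O=C(C1CCOCC1)N1CCc2nc(C#Cc3ccccc3)sc2C1`: > 10000 nM

Each of these values is a limit of this assay, not a number. Compound 3 stands at that limit, and nothing more is known of it; the same holds for compound 1 and for compound 2, so the limit of > 10000 nM in this assay, at which 3 of the 3 values shown sit, is the whole of the evidence. The steps a step that the two limits leave unreadable from compound 1 to compound 2, a step that the two limits leave unreadable from compound 1 to compound 3 and a step that the two limits leave unreadable from compound 2 to compound 3 therefore give no readable size and no direction.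

Compound 4 `O=C(N1CCCCC1)N1CCc2nc(C#Cc3ccccc3)sc2C1` is to be measured in this assay. It differs from compound 3 by piperidin-1-yl in place of oxan-4-yl on a carbonyl carbon, the carbonyl carbon otherwise carrying the amide-type nitrogen in a ring. Going by the values given here, none of the measured steps read, so no size or direction can be drawn for the step; the expectation is that a step that the limit leaves unreadable from compound 3 to compound 4 stays within the scatter and that compound 4 remains at the limit. Compound 4 is estimated at 15000 nM, in the range 5000 nM to 50000 nM.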

Compound 4, half-maximal inhibitory concentration: > 10000 nM
Compound 4: only a limit was reported; the forecaster's own chance of this, stated with the estimate: 85%; the middle value lies beyond the limit too.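

Compound 4, like compound 1, compound 2 and compound 3, gives only a limit in this assay, so no step among these compounds can be read: the limit of > 10000 nM in this assay, at which 4 of the 4 values shown sit.

The compounds shown leave open whether any group on this carbonyl carbon gives a measurable inhibitor on the shared core, and how such groups would rank.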